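Hydroxy-to-isopropoxy step on the acid-bearing ring

The source may hold more compounds than are shown below. What is called first, only, known or untested is meant among the compounds shown, and "the series" means these compounds.

Among the measured compounds shown here, compound 2 `CC(C)c1onc(-c2c(Cl)cccc2Cl)c1COc1ccc(-c2ccc3nc(C(=O)O)cc(O)c3c2)cc1` sits at the top of the two numbers recorded in a functional assay on CV-1 cells for agonist activity at Bile acid receptor (Homo sapiens), read by a luciferase reporter; a higher number here means that more compound is needed for the effect, a lower number that less compound is needed: in this assay compound 2 gives 10000 nM, while compound 1 `CC(C)c1onc(-c2c(Cl)cccc2Cl)c1COc1ccc(-c2ccc3cc(C(=O)O)ncc3c2)cc1`, the only neighbour, gives 77 nM in this assay, a gap far beyond the scatter. The two compounds differ in more than one place, so only their two values can be compared, not a single change.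

Compound 3 `CC(C)Oc1cc(C(=O)O)nc2ccc(-c3ccc(OCc4c(-c5c(Cl)cccc5Cl)noc4C(C)C)cc3)cc12` is not yet measured in this assay. It keeps the core of compound 2 and carries the change (isopropyl in place of hydrogen on an oxygen on an aromatic ring), the same difference one bond further out reading hydroxy to isopropoxy. For the measured compounds named here, no step between measured compounds covers this change, so the direction rests only on the high value of compound 2 in this assay. A moderate step downward, beyond the scatter, is expected for compound 3, as a 4.0-fold lower number from compound 2 to compound 3 (0.60 log units; beyond the scatter). The estimated value of compound 3 in this assay is 2500 nM, within 400 nM to 10000 nM.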

Compound 3, half-maximal effective concentration: 14 nM
The estimate for compound 3 lay 180-fold (2.25 log units) above the measured number, outside the stated range (below it).
By their numbers in this assay, from the lowest: compound 3; then compound 1; then compound 2.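

The hydroxy to isopropoxy change gives a 710-fold lower number from compound 2 to compound 3 (2.85 log units; beyond the scatter) in this assay, so the high number of compound 2 does not hold for this core as a whole. With the core kept, the group on this oxygen alone accounts for the whole gap, and isopropyl there is accepted. Among the compounds shown here, this is the first single change, since the earlier pair differed in more than one place, but no measurement on hand gives a reason for the step.

Only hydrogen and isopropyl are shown on this oxygen, so it remains open whether the number falls with the carbon count or needs the branched chain. Methyl, ethyl, a longer straight chain, or a chain ending in an amine on the same oxygen would address this.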